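Swapping Bromo for Methyl at the Same Aromatic Carbon

The compounds below may be only part of what the source reports. "The series", "measured", "known", "first", "only" and "open" are said of these compounds alone.

Among the measured compounds shown here, compound 2 `Cc1c(C(=O)Nc2ccc(Oc3ncnc4[nH]cc(-c5ccccc5)c34)c(F)c2)c(=O)c2cc(Br)ccc2n1C` was measured in an assay on isolated protein for inhibition of tyrosine-protein kinase receptor UFO (Homo sapiens), read by FRET and Z'-LYTE, with a stated time of 1.5 h (on this read-out higher numbers stand for weaker inhibition and lower numbers for stronger inhibition), and gives 3120 nM; compound 1 `Cc1c(C(=O)Nc2ccc(Oc3ncnc4[nH]cc(-c5ccccc5)c34)c(F)c2)c(=O)c2cc(Cl)ccc2n1C` gives 1890 nM, and the single measured step, a 1.7-fold higher number from compound 1 to compound 2 (0.22 log units; within the scatter), puts bromo in place of chloro and stays within the scatter, so the two compounds cannot be told apart. Compound 3 `Cc1ccc2c(c1)c(=O)c(C(=O)Nc1ccc(Oc3ncnc4[nH]cc(-c5ccccc5)c34)c(F)c1)c(C)n2C` differs from compound 2 in one place: methyl in place of bromo on an aromatic carbon. Because a 1.7-fold higher number from compound 1 to compound 2 (0.22 log units; within the scatter) stayed within the scatter when one halogen replaced another at this carbon, no change beyond the scatter is expected for compound 3 a 1.2-fold lower number from compound 2 to compound 3 (0.10 log units; within the scatter). Compound 3 is therefore estimated at 2500 nM, with a range from 1000 nM to 6500 nM.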

Compound 3, half-maximal inhibitory concentration: 100 nM
Beside the measured number, compound 3's estimate is 25-fold (1.40 log units) above it; measured number outside the range, below it.
By their numbers in this assay, from the lowest: compound 3; then compounds 1 and 2 (each within the scatter of the next).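

At this aromatic carbon, the choice of group can matter greatly: in this assay, methyl gives a 31-fold lower number from compound 2 to compound 3 (1.49 log units; beyond the scatter) and also a 19-fold lower number from compound 1 to compound 3 (1.28 log units; beyond the scatter). The swap between the two halogens had shown no difference beyond the scatter, so the similarity of chloro and bromo did not extend to methyl, and compound 3 has the lowest number of the three. No evidence here explains this large difference. Going by these compounds, whether an ethyl group, a longer chain, a methoxy group or an amine at this carbon would match methyl remains open.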